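From 4-propylphenyl to 3-fluorophenyl on the amide nitrogen

The source may report more compounds than this note shows. Statements on the series, on what has been measured and on what is new or still open speak of the compounds shown alone.

Compound 1 `CCCc1ccc(NC(=O)C2CCN(C/C=C/c3ccccc3)CC2)cc1`: 9470 nM
Compound 2 `CCCCc1ccc(NC(=O)C2CCN(C/C=C/c3ccccc3)CC2)cc1`: 5910 nM
Compound 3 `COc1ccc(NC(=O)C2CCN(C/C=C/c3ccccc3)CC2)cc1`: 83800 nM

In a functional assay on A549 cells (Homo sapiens) for inhibition, read by MTT assay, with a stated time of 72 h (a lower number here means a stronger inhibitor, a higher number a weaker inhibitor), compound 1 has the second highest of the three numbers. Compound 4 `O=C(Nc1cccc(F)c1)C1CCN(C/C=C/c2ccccc2)CC1` carries 3-fluorophenyl in place of 4-propylphenyl on an amide-type nitrogen. Within the data shown here, no measured step makes this exact exchange. The closest guides are an 8.8-fold higher number from compound 1 to compound 3 (0.95 log units; beyond the scatter) and a 14-fold higher number from compound 2 to compound 3 (1.15 log units; beyond the scatter), where methoxy replaces the alkyl chain. By contrast, a 1.6-fold lower number from compound 1 to compound 2 (0.20 log units; within the scatter) involves only the chain length. Among the measured compounds shown here, compound 4 also loses the propyl chain, so a modest step toward a higher number is expected in this assay, though no measured step shows how fluorine behaves here. The expected step is a 3.2-fold higher number from compound 1 to compound 4 (0.50 log units; beyond the scatter). For compound 4, the estimated value is 30000 nM, with an expected range of 11000 nM to 85000 nM.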

Compound 4, half-maximal inhibitory concentration: 43300 nM
Estimate against measurement, compound 4: 1.4-fold (0.16 log units) below; measured number inside the range.
By their numbers in this assay, from the lowest: compounds 2 and 1 (each within the scatter of the next); then compounds 4 and 3 (each within the scatter of the next).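

In this assay, 3-fluorophenyl in place of 4-propylphenyl gives a 4.6-fold higher number from compound 1 to compound 4 (0.66 log units; beyond the scatter) on the amide-type nitrogen, so compound 4 joins compound 3 as a second compound without an alkyl chain that stands beyond the scatter from compound 1. Set against the 4-methoxyphenyl group, the change gives a 1.9-fold lower number from compound 3 to compound 4 (0.29 log units; within the scatter), so this assay does not separate these two groups. No evidence at hand gives a cause for either step. Still open, going by these compounds, is how 4-fluorophenyl would compare with 3-fluorophenyl, and how an amine or a carboxylic acid on this ring would read.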